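The source may report more compounds than this note shows. Statements on the series, on what has been measured and on what is new or still open speak of the compounds shown alone.

Compound 1 `O=C(Nc1cccc(-c2oc3cc(-c4ccc(F)cc4)ccc3c(=O)c2O)c1)c1ccc(Cl)cc1` gives 12800 nM in a functional assay on MDA-MB-231 cells (Homo sapiens) for antiproliferative activity, read by CCK-8 assay, with a stated time of 72 h; a lower number here means a stronger inhibitor, a higher number a weaker inhibitor. Compound 2 `COc1cccc(C(=O)Nc2cccc(-c3oc4cc(-c5ccc(F)cc5)ccc4c(=O)c3O)c2)c1` gives 9160 nM in this assay.

Compound 2 carries the lowest of the two numbers shown, and its nearest neighbour is compound 1, which lies within the scatter of it. Within the data shown here, the only measured step, a 1.4-fold lower number from compound 1 to compound 2 (0.15 log units; within the scatter), replaces 4-chlorophenyl with 3-methoxyphenyl on the carbonyl carbon and stays within the scatter.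

Compound 3 `Cc1cc(C(=O)Nc2cccc(-c3oc4cc(-c5ccc(F)cc5)ccc4c(=O)c3O)c2)ccc1F` differs from compound 2 by 4-fluoro-3-methylphenyl in place of 3-methoxyphenyl on a carbonyl carbon. This change sits at the same place as the measured step, which bears on it: that step was small, so a shift in the aryl group on the carbonyl carbon left this assay unchanged beyond the scatter. The expected step of a 1.1-fold higher number from compound 2 to compound 3 (0.04 log units; within the scatter) is therefore no change beyond the scatter, in either direction. Compound 3 is estimated at 10000 nM, with a range from 4000 nM to 25000 nM.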

Compound 3, half-maximal inhibitory concentration: 7440 nM
For compound 3 the middle estimate is 1.3-fold (0.13 log units) above the measured one; the range from low to high includes it.
By their numbers in this assay, from the lowest: compounds 3, 2 and 1 (each within the scatter of the next).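

At the aryl group on the carbonyl carbon, 4-fluoro-3-methylphenyl in place of 3-methoxyphenyl gives a 1.2-fold lower number from compound 2 to compound 3 (0.09 log units; within the scatter) and in place of 4-chlorophenyl gives a 1.7-fold lower number from compound 1 to compound 3 (0.24 log units; within the scatter). All three substituted phenyl groups therefore read alike in this assay, even though the oxygen of 3-methoxyphenyl and the chlorine of 4-chlorophenyl have both given way to a group carrying fluorine and methyl. No independent evidence bears on this result.

The compounds shown leave open whether a different kind of group on this carbonyl carbon, such as a piperidine, a carboxylic acid on the phenyl ring or a longer alkyl chain, would move the number beyond the scatter. They also leave open how far any change to the shared core would matter.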